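The source may report more compounds than this note shows. Statements on the series, on what has been measured and on what is new or still open speak of the compounds shown alone.

The measured compounds are compound 2, `O=S(=O)(CSc1nnc(Br)n1Cc1ccc(Br)c2ccccc12)Nc1cccnc1Cl`, which in an assay on HEK293 cells for inhibition of solute carrier family 22 member 12 (Homo sapiens) (on this read-out higher numbers stand for weaker inhibition and lower numbers for stronger inhibition), gives 5100 nM, and compound 1, `O=S(=O)(CSc1nnc(Br)n1Cc1ccc(Br)c2ccccc12)Nc1cc(Cl)cnc1Cl`, for which this assay gives 2790 nM.

Among the compounds with values here, compound 2 is one of only two compounds measured, and its number sits close to that of compound 1: the step of a 1.8-fold higher number from compound 1 to compound 2 (0.26 log units; within the scatter) stays within the scatter, so the two values cannot be told apart on this read-out. Compound 3, `COc1ncccc1NS(=O)(=O)CSc1nnc(Br)n1Cc1ccc(Br)c2ccccc12`, has not yet been measured. It differs from compound 2 in one place: methoxy in place of chloro on an aromatic carbon. Within the data shown here, the only measured step, a 1.8-fold higher number from compound 1 to compound 2 (0.26 log units; within the scatter), concerns a different change at a different position on the same ring and gave no movement beyond the scatter; no measured pair tests methoxy in place of chloro on the aromatic carbon next to the ring nitrogen. Nothing in these numbers therefore points to a large step in this assay in either direction, and the expectation is a step of a 1.0-fold lower number from compound 2 to compound 3 (0.01 log units; within the scatter) that stays within the scatter. Compound 3 is expected to give 5000 nM, with a range from 1800 nM to 14000 nM.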

Compound 3, half-maximal inhibitory concentration: 4050 nM
The estimate for compound 3 lay 1.2-fold (0.09 log units) above the measured number; the range from low to high includes it.
By their numbers in this assay, from the lowest: compounds 1, 3 and 2 (each within the scatter of the next).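

In this assay, methoxy in place of chloro on the aromatic carbon next to the ring nitrogen, ortho to a large group, gives a 1.3-fold lower number from compound 2 to compound 3 (0.10 log units; within the scatter) and so leaves the read-out where it was, which shows that this position can carry methoxy as well as chloro without a change that can be told from the scatter. The wider exchange of 2,5-dichloropyridin-3-yl for 2-methoxypyridin-3-yl gives a 1.5-fold higher number from compound 1 to compound 3 (0.16 log units; within the scatter) and also stays level, so across the three compounds neither the chloro nor the methoxy on this ring has yet separated one value from another. The data offer no explanation for this flat result.

As far as these compounds go, it remains open whether any group at this position can move the number beyond the scatter in either direction, for instance an amine, a carboxylic acid or a longer chain such as ethoxy. Also open, from the compounds shown here alone, is how methoxy at this position behaves with the second chloro of compound 1 kept in place, and whether the shared core responds more strongly to change than this ring does.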